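The compounds below may be only part of what the source reports. "The series", "measured", "known", "first", "only" and "open" are said of these compounds alone.

Measured so far:
compound 1, `C/C=C(\CC)Oc1cc(C)nc(Oc2c(C)cc(C)cc2C)c1C`, 55% in a functional assay on the whole organism for displacement of a labelled ligand, with Rattus norvegicus as the target, at a dose of 3.2 mg/kg by the subcutaneous route; on this read-out higher numbers stand for more inhibition at the one dose given (going by the name of the read-out) and lower numbers for less inhibition;
compound 2, `CCc1c(OC(CC)CC)cc(C)nc1Oc1c(C)cc(C)cc1C`, 66%.

In this assay compound 2 gives the higher of the two numbers; the value of compound 1 is lower by a margin that exceeds the usual scatter. Going by the values given here, no step between the two measured compounds is given, so only the two values themselves can be compared. Compound 3, `CCC(CC)Oc1cc(C)nc(Oc2c(C)cc(C)cc2C)c1[N+](=O)[O-]`, has not yet been measured. It differs from compound 2 in one place: nitro in place of ethyl on an aromatic carbon. Among the compounds with values here, there is no measured precedent for such an exchange, so the direction of the step is uncertain. The author expects a small to moderate decrease from compound 2 to compound 3 in this assay, as stated by a number 11 percentage points lower from compound 2 to compound 3 (beyond the scatter), though a change within the scatter would not be surprising. Compound 3 is therefore estimated at 55%, with a range from 30% to 75%.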

Compound 3, a percentage reported as inhibition, in the whole organism at one dose (the size of the read-out at that dose, not a potency): 35%
Compound 3: middle estimate off by 20 percentage points, on the high side; measured number inside the range.
By their numbers in this assay, from the lowest: compound 3; then compound 1; then compound 2.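

In this assay, going by these compounds alone, the exchange of ethyl for nitro on the aromatic carbon ortho to the (pentan-3-yl)oxy group gives a number 31 percentage points lower from compound 2 to compound 3 (beyond the scatter) and is the only measured step. This position is therefore not indifferent to the group it carries: with the rest of the molecule unchanged, the exchange goes with clearly less inhibition at the one dose, although compound 3 still reaches 35% at that dose. No measurement at hand explains the step.

One step cannot show whether the loss is peculiar to nitro or would follow other replacements of ethyl here. Going by these compounds, whether an amine, a nitrile or a longer chain such as propyl on this carbon would hold the number of compound 2, or fall towards that of compound 3, stays open.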